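Swapping methoxy for fluoro on a thioether pair

The source may report more compounds than this note shows. Statements on the series, on what has been measured and on what is new or still open speak of the compounds shown alone.

Compound 1 `COc1cc(CNc2nc3cc(N)cc(N)c3nc2-c2ccccc2)cc(OC)c1OC` gives 19100 nM in a functional assay on HCT-116 cells (Homo sapiens) for inhibition, read by sulforhodamine B assay, with a stated time of 48 h; a lower number here means a stronger inhibitor of growth, a higher number a weaker inhibitor of growth.
Compound 2 `COc1ccc(Sc2nc3cc(N)cc(N)c3nc2-c2ccccc2)cc1` gives only a limit, < 100000 nM, in this assay.

From the compounds shown here alone, compound 2 therefore stands at the limit of < 100000 nM in this assay, at which 1 of the 2 values shown sits, and not at a measured number, so how far it falls under that bound is unknown. Compound 3 `Nc1cc(N)c2nc(-c3ccccc3)c(Sc3ccc(F)cc3)nc2c1` differs from compound 2 by fluoro in place of methoxy on an aromatic carbon. Going by the values given here, no measured step in this assay covers this change, and with compound 2 known only as a limit, the step is expected to be modest and within the usual scatter, in no clear direction. Compound 3 is expected at 40000 nM, between 10000 nM and 100000 nM, meaning a step that the limit leaves unreadable from compound 2 to compound 3.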

Compound 3, concentration for total growth inhibition: 28200 nM
Beside the measured number, compound 3's estimate is 1.4-fold (0.15 log units) above it, within the range that was stated.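

No step can be read from compound 2 to compound 3, because compound 2 is known only as a limit: the limit of < 100000 nM in this assay, at which 1 of the 3 values shown sits.

The compounds shown leave open whether fluoro in place of methoxy on this aromatic carbon changes the result in this assay at all.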